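Adding bromine to the phenyl ring of compound 3

A few compounds are considered here, and "the series" means these few. Any claim that something is new, unique, unknown or untested is made for them only; others in the source may bear on it.

All four compounds share one core, differing only in the aryl ring that hangs from the carbon double-bonded to nitrogen. Compound 1 `CN(C)CCn1cnnc1-c1cc(Oc2ccc(NC(=O)N/N=C/c3ccc(O)c(Br)c3)cc2F)ccn1` carries a 3-bromo-4-hydroxyphenyl there, and in an ADME assay on WI-38 cells (Homo sapiens) for cytotoxicity, read by MTT assay, with a stated time of 72 h (a higher number here means a weaker inhibitor, a lower number a stronger inhibitor), compound 1 gives 5560 nM. Compound 2 `CN(C)CCn1cnnc1-c1cc(Oc2ccc(NC(=O)N/N=C/c3ccccc3O[N+](=O)[O-])cc2F)ccn1` carries a 2-(nitrooxy)phenyl instead, and in this assay compound 2 gives 6860 nM. The step of a 1.2-fold higher number from compound 1 to compound 2 (0.09 log units; within the scatter) shows that swapping one substituted ring for another at this position left the read-out essentially unchanged. Compound 3 `CN(C)CCn1cnnc1-c1cc(Oc2ccc(NC(=O)N/N=C/c3ccccc3)cc2F)ccn1` carries a plain phenyl at the same position; in this assay compound 3 gives "not determined" (no result reported), so no single number places it among the others. Compound 4 `CN(C)CCn1cnnc1-c1cc(Oc2ccc(NC(=O)N/N=C/c3cccc(Br)c3)cc2F)ccn1` differs from compound 3 by bromo in place of hydrogen on an aromatic carbon, which turns the phenyl into a 3-bromophenyl. For the measured compounds named here, no measured step tracks exactly this change, and compound 3 itself has no value to start from. Going by the values given here, the only guidance comes from compounds 1 and 2, whose different aryl rings at this position gave values close to one another in this assay. On that basis compound 4 is expected to land near those two, with an estimated value of 6000 nM and a likely range from 2500 nM to 14000 nM.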

Compound 4, half-maximal inhibitory concentration: 4230 nM
Beside the measured number, compound 4's estimate is 1.4-fold (0.15 log units) above it; the measured number falls inside the stated range.
By their numbers in this assay, from the lowest: compounds 4, 1 and 2 (each within the scatter of the next).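

In this assay, a third aryl ring at this position keeps the read-out close to the other two: going to the 3-bromophenyl gives a 1.6-fold lower number from compound 2 to compound 4 (0.21 log units; within the scatter). For the compounds shown here, the new compound also gives the first comparison in which only one group on the ring changes, with hydrogen taking the place of hydroxy on the bromo-bearing ring, and that change gives a 1.3-fold lower number from compound 1 to compound 4 (0.12 log units; within the scatter). Both steps lie within the scatter, so among compounds 1, 2 and 4 neither the hydroxy nor the choice between these rings produces a difference that can be told apart from the noise of repeated measurements. Nothing at hand explains why these values sit so close together.

As far as these compounds go, the step from compound 3 to compound 4 cannot be read, so what bromo adds to the plain phenyl ring remains open. Also open, from the compounds shown here alone, is whether a ring carrying an amine or a carboxylic acid at this position, or a longer chain in place of the aryl ring, would stay in this same range of values.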